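Side chain on the core: compound 3 to compound 4

The source may hold more compounds than are shown below. What is called first, only, known or untested is meant among the compounds shown, and "the series" means these compounds.

In a functional assay on Raji cells (Homo sapiens) for antiproliferative activity, read by MTT assay, with a stated time of 48 h (on this read-out higher numbers stand for weaker inhibition and lower numbers for stronger inhibition), compound 3 `N#Cc1nc2c(-c3nc4ccccc4[nH]3)c(N)n(CCCO)c2nc1C#N` gives > 50000 nM, which is a limit and not a number. Compound 1 `Cn1c(N)c(-c2nc3ccccc3[nH]2)c2nc(C#N)c(C#N)nc21` gives > 50000 nM, also a limit. Compound 2 `N#Cc1nc2c(-c3nc4ccccc4[nH]3)c(N)n(CCO)c2nc1C#N` gives 5520 nM. Compound 3 thus stands at the limit of > 50000 nM in this assay, at which 2 of the 3 values shown sit.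

Compound 4 `CCN(CC)CCCCn1c(N)c(-c2nc3ccccc3[nH]2)c2nc(C#N)c(C#N)nc21` carries (diethylamino)methyl in place of hydroxy on a saturated chain carbon, three bonds along the chain from an aromatic nitrogen, which reads as 3-hydroxypropyl to 4-(diethylamino)butyl. The bearing steps are an at least 9.0-fold lower number from compound 1 to compound 2 (0.95 log units; beyond the scatter) and an at least 9.0-fold higher number from compound 2 to compound 3 (0.95 log units; beyond the scatter), while a step that the two limits leave unreadable from compound 1 to compound 3. Among the measured compounds shown here, no measured step carries a diethylamino chain. A modest step to a lower number in this assay is expected, of the size seen in an at least 9.0-fold lower number from compound 1 to compound 2 (0.95 log units; beyond the scatter). The estimate means an at least 4.1-fold lower number from compound 3 to compound 4 (0.61 log units; beyond the scatter). For compound 4 the expected value is 12000 nM, with an estimated range of 2500 nM to 50000 nM.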

Compound 4, half-maximal inhibitory concentration: 2640 nM
Compound 4: middle estimate off by 4.5-fold (0.66 log units), on the high side; low and high end bracket the measured number.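

In this assay, a chain ending in diethylamino gives a readable number where the 3-hydroxypropyl chain gave only a limit (an at least 18-fold lower number from compound 3 to compound 4 (1.27 log units; beyond the scatter)), and the same holds against the small substituent of compound 1 (an at least 18-fold lower number from compound 1 to compound 4 (1.27 log units; beyond the scatter)). Over the 2-hydroxyethyl chain the change is much smaller, though still beyond the scatter (a 2.1-fold lower number from compound 2 to compound 4 (0.32 log units; beyond the scatter)). The two larger steps rest on limits, not numbers: (the limit of > 50000 nM in this assay, at which 2 of the 4 values shown sit).

Open, from the compounds shown here alone, is whether the change belongs to the amine or to the chain length. A 4-hydroxybutyl chain, or a pyrrolidine or morpholine in place of diethylamino, would separate the two.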